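Replacing the aryl group on the shared core of compound 2

The source may hold more compounds than are shown below. What is called first, only, known or untested is meant among the compounds shown, and "the series" means these compounds.

In a functional assay on HepG2 cells (Homo sapiens) for antiproliferative activity, read by CCK-8 assay, with a stated time of 72 h, tested at 8 uM (on this read-out lower numbers stand for a weaker effect and higher numbers for a stronger effect at the one concentration tested), compound 1 `Nc1ccccc1NC(=O)c1ccc(Cn2cnc3c(NCc4ccccc4)nc(Cl)nc32)cc1` gives 62.8%, and compound 2 `Nc1ccccc1NC(=O)c1ccc(Cn2cnc3c(Nc4ccc(-c5ccccn5)cc4)nc(Cl)nc32)cc1` gives 41.2%. Among the two numbers measured, compound 2 stands lowest; its nearest neighbour is compound 1, and the step of a number 21.6 percentage points lower from compound 1 to compound 2 (beyond the scatter) lies beyond the scatter. Compound 3 `Nc1ccccc1NC(=O)c1ccc(Cn2cnc3c(Nc4cccc(OC(F)(F)F)c4)nc(Cl)nc32)cc1` has not been measured. It differs from compound 2 in one place: 3-(trifluoromethoxy)phenyl in place of 4-(pyridin-2-yl)phenyl on a nitrogen on an aromatic ring. Among the measured compounds shown here, the single measured step bears on this change only in part, since it exchanged benzyl for an aryl group on that nitrogen, whereas here one aryl group replaces another. A step of modest size in either direction, or none beyond the scatter, is therefore expected in this assay, with the change a number 3.8 percentage points higher from compound 2 to compound 3 (within the scatter) as the estimate. Compound 3 is estimated at 45%, within a range from 25% to 65%.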

Compound 3, a percentage reported as inhibition, at one concentration (the size of the read-out at that concentration, not a potency): 31.2%
Estimate against measurement, compound 3: 13.8 percentage points above, within the range that was stated.
By their numbers in this assay, from the lowest: compounds 3 and 2 (each within the scatter of the next); then compound 1.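

In this assay, exchanging one aryl group for another on this nitrogen gives a number 10 percentage points lower from compound 2 to compound 3 (within the scatter), so 3-(trifluoromethoxy)phenyl and 4-(pyridin-2-yl)phenyl are not separated here, although the groups differ in their rings and atoms. Exchanging benzyl for 3-(trifluoromethoxy)phenyl gives a number 31.6 percentage points lower from compound 1 to compound 3 (beyond the scatter), so a second, quite different aryl group also stands apart from the benzyl of compound 1, and among these three compounds none goes against that division. Nothing available explains either step.

Going by these compounds, it remains open whether a phenethyl group on this nitrogen, or an amine or a carboxylic acid on the ring of the benzyl group, would hold the level of compound 1. Equally open, on these data alone, is whether a plain phenyl group there would fall with the two aryl groups tested.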